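Replacing Chloro with 4-Fluorophenoxy on the Pyridine-Linked Core

The source may hold more compounds than are shown below. What is called first, only, known or untested is meant among the compounds shown, and "the series" means these compounds.

Measured compounds:
compound 1, `FC(F)(F)Oc1cccc(Oc2ccnc(N3CCC(NC(=S)Nc4cccnc4)CC3)c2Cl)c1`, 89 nM
compound 2, `S=C(Nc1cccnc1)NC1CCN(c2cc(Cl)ccn2)CC1`, 2100 nM

Both compounds were tested in an assay on membranes from brain for binding affinity to Lysophosphatidylserine lipase ABHD12 (Mus musculus), read by fluorescence, with a stated time of 20 min; on this read-out higher numbers stand for weaker inhibition and lower numbers for stronger inhibition. Compound 2 gives 2100 nM, the highest of the two numbers and therefore the weaker inhibitor; its nearest neighbour, compound 1, gives 89 nM, a gap well beyond the scatter of repeated measurements. Compound 1 carries a much larger substituent on the shared core than compound 2, so the two values only show that a bulkier compound of this family can reach a far lower number.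

Compound 3, `Fc1ccc(Oc2ccnc(N3CCC(NC(=S)Nc4cccnc4)CC3)c2)cc1`, has not yet been measured in this assay. It differs from compound 2 in one place: 4-fluorophenoxy in place of chloro on an aromatic carbon. The group that enters sits on the aromatic carbon that is meta to a large group and opposite the ring nitrogen, where compound 2 holds only a chloro.

Given that compound 1, which also carries an aryloxy group there, gives 89 nM, a step toward lower numbers is expected, and compound 3 is estimated at 350 nM with a range of 90 nM to 1400 nM. The expected step of a 6.0-fold lower number from compound 2 to compound 3 (0.78 log units; beyond the scatter) is beyond the scatter.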

Compound 3, half-maximal inhibitory concentration: 1400 nM
Estimate against measurement, compound 3: 4.0-fold (0.60 log units) below, and the stated range covers the measured number.
By their numbers in this assay, from the lowest: compound 1; then compounds 3 and 2 (each within the scatter of the next).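

In this assay the change shows a 1.5-fold lower number from compound 2 to compound 3 (0.18 log units; within the scatter), so compound 2 and compound 3 cannot be told apart, even though the single chloro gives way to 4-fluorophenoxy, a group of 8 heavy atoms with an aromatic ring of its own. Among the compounds shown here, on this aromatic carbon, opposite the ring nitrogen, a far larger group is therefore accepted with no measurable change in the read-out, but an aryloxy group here is not enough on its own to reach a number like the one compound 1 gives, 89 nM. Nothing measured here explains why the two values match.

As far as these compounds go, compound 1 differs from compound 3 in more than one place, including an extra chloro on the shared core and trifluoromethoxy in place of fluoro on the outer aromatic ring, so it remains open which of these differences goes with its lower number. From the compounds shown here alone, it also remains open how other groups on this same carbon would read, such as an amine, a methoxy group or a carboxylic acid.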